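The source may hold more compounds than are shown below. What is called first, only, known or untested is meant among the compounds shown, and "the series" means these compounds.

Working notes on the series, read in a functional assay on HT-29 cells (Homo sapiens) for antiproliferative activity, read by sulforhodamine B assay, with a stated time of 48 h; on this read-out higher numbers stand for weaker inhibition and lower numbers for stronger inhibition. Compound 1 `O=C1NCCN1c1ccc(S(=O)(=O)Nc2ccc(C3CCCCC3)cc2)cc1` gives > 1000 nM, which is a limit of the assay and not a number. Compound 2 `O=C1NCCN1c1ccc(S(=O)(=O)Nc2ccc(I)cc2)cc1` gives 650 nM, and the change from cyclohexyl to iodo gives an at least 1.5-fold lower number from compound 1 to compound 2 (0.18 log units; that floor lies within the scatter). Compound 3 `CCc1cccc(NS(=O)(=O)c2ccc(N3CCNC3=O)cc2)c1` gives 110 nM, the lower of the two actual numbers in the series.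

Compound 4 `Cc1ccc(NS(=O)(=O)c2ccc(N3CCNC3=O)cc2)c(C)c1` has 2,4-dimethylphenyl in place of 3-ethylphenyl on a sulfonamide nitrogen. Among the compounds with values here, two measured steps bear on this change. The closer one also replaces the group on the sulfonamide nitrogen and gives a 5.9-fold lower number from compound 2 to compound 3 (0.77 log units; beyond the scatter), so rearranging this group can move the number by a modest amount. The other step, an at least 1.5-fold lower number from compound 1 to compound 2 (0.18 log units; that floor lies within the scatter), rests on a limit and adds little. With only these steps to go on, a small shift towards a higher number is expected, with none beyond the scatter. The expected step is a 1.6-fold higher number from compound 3 to compound 4 (0.21 log units; within the scatter). For compound 4 the estimate is 180 nM, with an expected range of 60 nM to 600 nM.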

Compound 4, half-maximal inhibitory concentration: 180 nM
Estimate against measurement, compound 4: no gap at the digits printed; the measured number falls inside the stated range.
By their numbers in this assay, from the lowest: compounds 3 and 4 (each within the scatter of the next); then compound 2. At a limit, above all of these: compound 1.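

Changing 3-ethylphenyl to 2,4-dimethylphenyl on the sulfonamide nitrogen gives a 1.6-fold higher number from compound 3 to compound 4 (0.21 log units; within the scatter) in this assay and so does not separate these two groups, which have the same atoms joined differently. The earlier compounds shown here showed only that this position could move the number; this pair shows that one rearrangement of the group there leaves the reading within the scatter. The step of a 3.6-fold lower number from compound 2 to compound 4 (0.56 log units; beyond the scatter) gives a second reading away from 4-iodophenyl, in the same direction as the step from compound 2 to compound 3, so that gap does not rest on 3-ethylphenyl alone.

Still open, going by these compounds, is what an amine or a carboxylic acid on the aromatic ring of this group would do, and whether either methyl of 2,4-dimethylphenyl matters on its own. Compound 1 remains at > 1000 nM, a limit and not a number: the limit of > 1000 nM in this assay, at which 1 of the 4 values shown sits.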